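This account rests on a few compounds, and the source may have more. Where it says the series, first, only, none or still open, it means among the compounds named here.

Measured compounds in a functional assay on CCRF-CEM cells (Homo sapiens) for cytotoxicity, read by MTT assay, with a stated time of 72 h; a lower number here means that less compound is tolerated, a higher number that more compound is tolerated:

Compound 1 `CSc1nc(NCCCCCO)c2cccnc2n1`: compound 1 gives > 100000 nM, a limit of the assay and not a number.
Compound 2 `CSc1nc(NCc2ccccc2)c2ccccc2n1`: compound 2 gives > 100000 nM, likewise a limit.
Compound 3 `CSc1nc(NCc2ccccc2)c2cccnc2n1`: compound 3 gives > 100000 nM, likewise a limit.

Notes. All three measured values sit at the same limit, as the limit of > 100000 nM in this assay, at which 3 of the 3 values shown sit, records, so no ordering among compounds 1, 2 and 3 can be read from them. Going by the values given here, the one change made between measured compounds is 4-hydroxybutyl in place of phenyl on a saturated chain carbon bound to a nitrogen on an aromatic ring; its step in this assay is a step that the two limits leave unreadable from compound 3 to compound 1, which the two limits leave unreadable. The difference between the core of compound 2 and the core of compound 3 is not broken down here.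

Compound 4 `CSc1nc(NCCCCCO)c2ccccc2n1` is not yet measured. It differs from compound 2 by 4-hydroxybutyl in place of phenyl on a saturated chain carbon bound to a nitrogen on an aromatic ring, the same kind of change as that from compound 3 to compound 1, at the same place. Since compound 2 already sits at a limit, and since the same change between compound 3 and compound 1 left both at the limit, the step that the limit leaves unreadable from compound 2 to compound 4 from compound 2 to compound 4 is expected to be small and most likely to remain unreadable. For compound 4 the expected value in this assay is 150000 nM, with a range from 60000 nM to 400000 nM, and it is estimated that the assay will again report only a limit.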

Compound 4, concentration lethal to 50% of the cells: > 100000 nM
Compound 4 was reported as a limit (the forecaster's own chance of this, stated with the estimate: 85%); the middle value does not contradict the limit.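

Compound 2 and compound 4 both sit at a limit of the assay and not at a number, so no step can be read between them, because the change from phenyl to 4-hydroxybutyl stays hidden at that limit: the limit of > 100000 nM in this assay, at which 4 of the 4 values shown sit.

The compounds shown leave open how far compounds 1, 2, 3 and 4 each lie beyond that limit, and whether either the chain change or the core difference alters cytotoxicity at all.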